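A few compounds are considered here, and "the series" means these few. Any claim that something is new, unique, unknown or untested is made for them only; others in the source may bear on it.

Two compounds of the shared core carry a measurement in an assay on HEK293 cells for displacement of a labelled ligand from adenosine receptor A2b (Homo sapiens), with a stated time of 30 min; a lower number here means a stronger inhibitor, a higher number a weaker inhibitor. Compound 1 `CCCOC(=O)C1=C(C)NC(=O)NC1c1ccco1` gives 206 nM in this assay, and compound 2 `CCOC(=O)C1=C(CC)NC(=O)NC1c1ccco1` gives 715 nM, the higher of the two numbers, standing beyond the scatter from compound 1; the two differ in more than one place, so no single change can be read from them. Compound 3 `CCCC1=C(C(=O)OCC)C(c2ccco2)NC(=O)N1` is not yet measured. It differs from compound 2 by methyl in place of hydrogen on a saturated chain carbon, two bonds along the chain from a double-bonded ring carbon, that is, ethyl to propyl. Among the compounds with values here, no comparable one-place step is available in this assay, so the expected step from compound 2 to compound 3 is estimated small, a 1.1-fold lower number from compound 2 to compound 3 (0.04 log units; within the scatter), with no clear direction. Compound 3 is estimated at 650 nM in this assay, within 220 nM to 1900 nM.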

Compound 3, inhibition constant: 256 nM
For compound 3 the middle estimate is 2.5-fold (0.40 log units) above the measured one, and the stated range covers the measured number.
By their numbers in this assay, from the lowest: compounds 1 and 3 (each within the scatter of the next); then compound 2.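

In this assay, within the data shown here, the change from ethyl to propyl gives a 2.8-fold lower number from compound 2 to compound 3 (0.45 log units; beyond the scatter) and is the first one-place step available. A single added methyl on a saturated chain carbon, two bonds along the chain from a double-bonded ring carbon, is therefore enough to shift the number at this position. No measurement at hand accounts for this step.

A butyl chain would show whether the number keeps falling with length or turns back. From the compounds shown here alone, whether a branched isopropyl group or a terminal amine would be tolerated at this position also remains open.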